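A few compounds are considered here, and "the series" means these few. Any claim that something is new, unique, unknown or untested is made for them only; others in the source may bear on it.

Measured compounds in a functional assay on HT-1080 cells (Homo sapiens) for antiproliferative activity, read by sulforhodamine B assay, with a stated time of 48 h; on this read-out lower numbers stand for stronger inhibition and higher numbers for weaker inhibition: compound 1 `CC(=O)Nc1ccc(S(=O)(=O)Oc2ccccc2C(C)C)cc1` gives 12000 nM; compound 2 `CC(C)c1ccccc1OS(=O)(=O)c1ccc(NC(=O)CCCCl)cc1` gives 3800 nM.

Compound 2 holds the lowest of the two numbers; the nearest is compound 1, and the step of a 3.2-fold lower number from compound 1 to compound 2 (0.50 log units; beyond the scatter) lies beyond the scatter. Compound 3 `CC(C)c1ccccc1OS(=O)(=O)c1ccc(NC(=O)NC2CCCC2)cc1` differs from compound 2 by cyclopentylamino in place of 3-chloropropyl on a carbonyl carbon. Among the measured compounds shown here, the only measured step, from compound 1 to compound 2, extends the chain on the saturated carbon bound to the carbonyl and does not remove that chain, so it bears on the present change only loosely: it shows that the group on the carbonyl carbon can shift the number in this assay by a modest amount. For the measured compounds named here, no measured pair exchanges a chain for an amino-linked ring here. The expected step of a 1.2-fold higher number from compound 2 to compound 3 (0.07 log units; within the scatter) is therefore small, with no clear direction. Compound 3 is estimated at 4500 nM, within 1300 nM to 15000 nM.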

Compound 3, half-maximal inhibitory concentration: 3900 nM
Compound 3: the middle estimate sits 1.2-fold (0.06 log units) above what was measured; low and high end bracket the measured number.
By their numbers in this assay, from the lowest: compounds 2 and 3 (each within the scatter of the next); then compound 1.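

The exchange of 3-chloropropyl for cyclopentylamino on a carbonyl carbon gives, in this assay, a 1.0-fold higher number from compound 2 to compound 3 (0.01 log units; within the scatter), so this position takes a five-membered carbon ring and a hydrogen-bond donor with the two numbers inside the scatter of each other. Measured against methyl on the same carbon, cyclopentylamino gives a 3.1-fold lower number from compound 1 to compound 3 (0.49 log units; beyond the scatter), so a number at this level does not depend on a chlorine-bearing open chain. No measured evidence explains why these two different groups read alike.

Going by these compounds, whether the chlorine of 3-chloropropyl contributes anything of its own stays open, and a plain propyl on the carbonyl carbon would address that. Also open, on these data alone, is how a larger ring, as in cyclohexylamino, or an open-chain butylamino would read on that carbon.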